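A few compounds are considered here, and "the series" means these few. Any claim that something is new, unique, unknown or untested is made for them only; others in the source may bear on it.

Measured in a functional assay on RPMI-8226 cells (Homo sapiens) for inhibition; on this read-out higher numbers stand for weaker inhibition and lower numbers for stronger inhibition:
- Compound 1 `CC(C)(C)NC(=O)N1CC1C#N` gives 216000 nM
- Compound 2 `CCOC(=O)c1ccc(NC(=O)N2CC2C#N)cc1` gives 3000 nM

Compound 2 holds the lower of the two numbers, and its gap to compound 1 lies beyond the scatter. Compound 3 `N#CC1CN1C(=O)Nc1ccc(S(N)(=O)=O)cc1` has not yet been measured. It carries sulfamoyl in place of ethoxycarbonyl on an aromatic carbon, para to a group of 8 heavy atoms (sulfamoyl in place of ethoxycarbonyl on an aromatic carbon). Among the measured compounds shown here, no measured pair differs in one place only, so the data offer no direct guide to this change. With compound 2 at 3000 nM as the closest reference, a moderate move towards a higher number, meaning weaker inhibition, is expected in this assay. The estimated step is a 2.7-fold higher number from compound 2 to compound 3 (0.43 log units; beyond the scatter), though a result within the scatter would not be surprising. Compound 3 is expected at about 8000 nM, with an estimated range from 2000 nM to 35000 nM.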

Compound 3, half-maximal inhibitory concentration: > 38000 nM
Compound 3: only a limit was reported (the forecaster's own chance of this, stated with the estimate: 5%); middle value at least 4.7-fold (0.67 log units) from the limit.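

Among the compounds shown here, replacing ethoxycarbonyl with sulfamoyl on an aromatic carbon, para to a group of 8 heavy atoms, is the first change in one place, and in this assay it gives an at least 12-fold higher number from compound 2 to compound 3 (1.10 log units; beyond the scatter). The result for compound 3, > 38000 nM, is a limit and not a number. The step therefore shows that inhibition at this position depends on the group it carries, but it gives only a lower bound on the size of the change, and that bound rests on a single pair: the limit of > 38000 nM in this assay, at which 1 of the 3 values shown sits.

The compounds shown leave open how much weaker compound 3 really is and whether the loss is specific to sulfamoyl. A carboxylic acid, an amine or a methoxycarbonyl group at the same place on the core of compound 2 would test how narrow the tolerance at this position is.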